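This account rests on a few compounds, and the source may have more. Where it says the series, first, only, none or still open, it means among the compounds named here.

Measured so far in the series:
- compound 1 `Cc1c(NC(=O)c2ccc(C(C)(C)C)cc2)cccc1-c1ccnc2[nH]c(-c3cnn(C)c3)nc12`: 0.6 10^-6 cm/s
- compound 2 `Cn1cc(-c2nc3c(-c4ccc(CNC(=O)c5nc(C(C)(C)C)no5)c(F)c4)ccnc3[nH]2)cn1`: 11 10^-6 cm/s
- compound 3 `Cn1cc(-c2nc3c(-c4ccc(CN5CCc6cc(C(C)(C)C)ccc6C5=O)c(F)c4)ccnc3[nH]2)cn1`: 0.2 10^-6 cm/s

In an ADME assay on Caco-2 cells (Homo sapiens) for permeability, in the apical to basolateral direction (on this read-out higher numbers stand for higher permeability and lower numbers for lower permeability), compound 2 stands highest of the three numbers. The nearest of the others is compound 1 with 0.6 10^-6 cm/s, a gap beyond the usual scatter; the furthest is compound 3 with 0.2 10^-6 cm/s, also beyond the scatter. All three share the same core, and the differences lie entirely in the group carried on the amide-type nitrogen side of the molecule.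

The next compound, compound 4 `CC1CC2(C1)CN(C(=O)NCc1ccc(-c3ccnc4[nH]c(-c5cnn(C)c5)nc34)cc1F)C2`, differs from compound 2 in one place: a group of 8 heavy atoms (7 carbon, 1 nitrogen; one four-membered non-aromatic ring of carbon only, one four-membered non-aromatic ring with 1 hetero atom) in place of a group of 9 heavy atoms (6 carbon, 2 nitrogen, 1 oxygen; one five-membered aromatic ring with 3 hetero atoms), on a carbonyl carbon. Within the data shown here, no pair of measured compounds isolates a change of this kind, so the expected step rests on the standing of compound 2 alone and on the nature of the exchange. A moderate downward movement in this assay is expected, most likely near the edge of the scatter rather than far beyond it, since compound 2 gives 11 10^-6 cm/s and the carbonyl and the amide-type nitrogen are kept.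

Compound 4 is therefore expected to give 5 10^-6 cm/s, with a range from 1.5 10^-6 cm/s to 15 10^-6 cm/s. This corresponds to an expected step of a 2.2-fold lower number from compound 2 to compound 4 (0.34 log units; beyond the scatter).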

Compound 4, apparent permeability: 8 10^-6 cm/s
Compound 4: the middle estimate sits 1.6-fold (0.20 log units) below what was measured; the range from low to high includes it.
By their numbers in this assay, from the lowest: compound 3; then compound 1; then compounds 4 and 2 (each within the scatter of the next).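

In this assay, the group with one five-membered aromatic ring with 3 hetero atoms gives way to the group with one four-membered non-aromatic ring of carbon only and one four-membered non-aromatic ring with 1 hetero atom, on a carbonyl carbon whose other neighbour is an amide-type nitrogen, and this first one-place comparison in the series reads a 1.4-fold lower number from compound 2 to compound 4 (0.14 log units; within the scatter). At this place, then, the two compounds cannot be told apart on this read-out, although the group that enters has no aromatic ring and 0 hydrogen-bond acceptors where the group that leaves has 3 hydrogen-bond acceptors. Nothing in the data shown offers a reason for this outcome.

From the compounds shown here alone, whether the read-out stays at this level with a morpholine or a dimethylamino group on the same carbonyl carbon remains open. Compound 1 at 0.6 10^-6 cm/s and compound 3 at 0.2 10^-6 cm/s are joined to compound 2 and compound 4 by no one-place change, so no single structural change can be linked to their numbers.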